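From 4-chlorophenyl to pyridin-4-yl on a shared core

The source may hold more compounds than are shown below. What is called first, only, known or untested is meant among the compounds shown, and "the series" means these compounds.

Measured in a functional assay on MOLT-4 cells (Homo sapiens) for antiproliferative activity; on this read-out lower numbers stand for stronger inhibition and higher numbers for weaker inhibition:
Compound 1 `COc1cc(C(=O)c2sc(-c3ccc(Cl)cc3)cc2N)cc(OC)c1OC`: 77 nM
Compound 2 `COc1cc(C(=O)c2sc(-c3ccc(I)cc3)cc2N)cc(OC)c1OC`: 190 nM
Compound 3 `COc1cc(C(=O)c2sc(-c3cccc([N+](=O)[O-])c3)cc2N)cc(OC)c1OC`: 7.5 nM

Compound 1 holds the middle place, with the second highest of the three numbers. Compound 4 `COc1cc(C(=O)c2sc(-c3ccncc3)cc2N)cc(OC)c1OC` is still unmeasured and differs from compound 1 by pyridin-4-yl in place of 4-chlorophenyl on an aromatic carbon. Two measured steps change this same group. Swapping only the halogen gave a 2.5-fold higher number from compound 1 to compound 2 (0.39 log units; beyond the scatter), whereas 3-nitrophenyl gave a 10-fold lower number from compound 1 to compound 3 (1.01 log units; beyond the scatter). Neither step introduces a ring nitrogen, so the guide is loose. In this assay a small move toward a higher number is expected, perhaps none beyond the scatter. The estimated change is a 1.6-fold higher number from compound 1 to compound 4 (0.19 log units; within the scatter). For compound 4 the expected value is 120 nM, within an estimated range from 20 nM to 700 nM.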

Compound 4, half-maximal inhibitory concentration: 88 nM
Compound 4: the middle estimate sits 1.4-fold (0.13 log units) above what was measured; low and high end bracket the measured number.
By their numbers in this assay, from the lowest: compound 3; then compounds 1 and 4 (each within the scatter of the next); then compound 2.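

In this assay, pyridin-4-yl takes the place of 4-chlorophenyl on the shared core with a 1.1-fold higher number from compound 1 to compound 4 (0.06 log units; within the scatter), so a carbon-only ring bearing a halogen is not required at this position to reach this level. Pyridin-4-yl still differs from the other two groups, with a 2.2-fold lower number from compound 2 to compound 4 (0.33 log units; beyond the scatter) and a 12-fold higher number from compound 3 to compound 4 (1.07 log units; beyond the scatter), leaving 3-nitrophenyl in compound 3 well ahead. No measurement here explains these differences. Still open, going by these compounds, is whether pyridin-3-yl would match pyridin-4-yl, and whether 3-aminophenyl would keep the strength seen with 3-nitrophenyl.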